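Swapping the Thioether Heteroaryl for a Pyrimidinyl Ether

A few compounds are considered here, and "the series" means these few. Any claim that something is new, unique, unknown or untested is made for them only; others in the source may bear on it.

Compound 3 `CC(C)[C@H](NC(=O)COc1cccc2ccccc12)C(=O)N[C@@H](CC(=O)O)C(=O)CSc1nc2ccccc2[nH]1` shares its core with compound 1 `CC(C)[C@H](NC(=O)COc1cccc2ccccc12)C(=O)N[C@@H](CC(=O)O)C(=O)CSc1nccn1C` and compound 2 `CC(C)[C@H](NC(=O)COc1cccc2ccccc12)C(=O)N[C@@H](CC(=O)O)C(=O)CSc1nncn1C`; the three differ only in the heteroaryl carried on the sulfur. In a functional assay on Jurkat cells (Homo sapiens) for inhibition (a higher number here means a weaker inhibitor, a lower number a stronger inhibitor), compound 1 reaches only the limit > 200000 nM. Compound 2 likewise stops at the limit > 200000 nM in this assay. Compound 3 also sits at the limit > 200000 nM in this assay. All three values thus rest at the limit of > 200000 nM in this assay, at which 3 of the 3 values shown sit, so none of the compounds can be ranked against the others, and the steps a step that the two limits leave unreadable from compound 1 to compound 2, a step that the two limits leave unreadable from compound 1 to compound 3 and a step that the two limits leave unreadable from compound 2 to compound 3 give no readable size.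

Compound 4 `CC(C)[C@H](NC(=O)COc1cccc2ccccc12)C(=O)N[C@@H](CC(=O)O)C(=O)COc1nccc(C(F)(F)F)n1` is the unmeasured member. Its change from compound 3 is (4-(trifluoromethyl)pyrimidin-2-yl)oxy in place of (1H-benzimidazol-2-yl)sulfanyl on a saturated chain carbon bound to a carbonyl carbon. Among the compounds with values here, no measured step covers the exchange of a sulfur link for an oxygen link, nor the entry of a trifluoromethyl-bearing six-membered ring with two hetero atoms; the measured steps only show that three different heteroaryls on the sulfur all left the value at the limit. Compound 4 is therefore expected to give about 150000 nM in this assay, within 20000 nM to 200000 nM, most probably again reported only as a limit. Within the data shown here, the expected step of an at least 1.3-fold lower number from compound 3 to compound 4 (0.12 log units; that floor lies within the scatter) is an estimate resting on no measured precedent.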

Compound 4, half-maximal inhibitory concentration: > 200000 nM
Compound 4: only a limit was reported (the forecaster's own chance of this, stated with the estimate: 70%); at least 1.3-fold (0.12 log units) between middle value and limit.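

Within the data shown here, no step to compound 4 from compound 1, compound 2 or compound 3 can be read, as all four compounds rest at the same limit: the limit of > 200000 nM in this assay, at which 4 of the 4 values shown sit.

The compounds shown leave open whether any of these groups on the shared core gives a measurable inhibition in this assay and how an oxygen link compares with a sulfur link.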